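Fluoro on the Fused Ring: From Thiourea Pair to Amine Pair

The compounds below may be only part of what the source reports. "The series", "measured", "known", "first", "only" and "open" are said of these compounds alone.

The study compares two related series. Compound 1 `Fc1ccc(NC(=S)Nc2nc3ccccc3s2)cc1` is the parent of the first pair, and in a functional assay on U-937 cells (Homo sapiens) for cytotoxicity, read by MTT assay, with a stated time of 48 h (on this read-out lower numbers stand for stronger inhibition and higher numbers for weaker inhibition), compound 1 gives 32100 nM. Compound 3 `Fc1ccc(NC(=S)Nc2nc3ccc(F)cc3s2)cc1` carries a single added substituent, and in this assay compound 3 gives 16200 nM. The change that separates them is fluoro in place of hydrogen on an aromatic carbon, and it produces a 2.0-fold lower number from compound 1 to compound 3 (0.30 log units; within the scatter).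

Compound 2 `Clc1cccc2sc(Nc3nc4ccccc4s3)nc12` opens the second pair. In this assay compound 2 gives only a limit, > 50000 nM, which is the upper edge of the measurement rather than a number. This is the situation described by the limit of > 50000 nM in this assay, at which 1 of the 3 values shown sits. How the core of compound 2 differs from the core of compound 1 is not broken down here.

Compound 4 `Fc1ccc2nc(Nc3nc4c(Cl)cccc4s3)sc2c1` has not yet been measured in this assay. It differs from compound 2 by fluoro in place of hydrogen on an aromatic carbon. The place of the new fluoro is described in the same words for both pairs, so the change from compound 2 to compound 4 is the same as the change from compound 1 to compound 3.

On that basis, the expected step is an at least 1.1-fold lower number from compound 2 to compound 4 (0.04 log units; that floor lies within the scatter), set beside the measured 2.0-fold lower number from compound 1 to compound 3 (0.30 log units; within the scatter), and it rests on the fact that compound 1 gives 32100 nM while compound 3 gives 16200 nM. Because compound 2 gives > 50000 nM, a starting point that is itself a limit, compound 4 is estimated at 45000 nM in this assay, with a range from 20000 nM to 100000 nM, and the assay may again report only a limit.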

Compound 4, half-maximal inhibitory concentration: 50000 nM
Compound 4: the middle estimate sits 1.1-fold (0.05 log units) below what was measured, within the range that was stated.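

In this assay compound 2 gives > 50000 nM, which is a limit and not a number, so the size of the step to compound 4 cannot be read. All that can be given is a number no higher from compound 2 to compound 4 (the limit leaves the size open). Set side by side, the two pairs give this picture: the same change on two cores in this assay, a 2.0-fold lower number (0.30 log units; within the scatter) from compound 1 to compound 3 and a number no higher (the limit leaves the size open) from compound 2 to compound 4; the limit leaves it open whether they differ

What this shows is modest: fluoro in place of hydrogen on an aromatic carbon gives no sign of a higher number on the second core, so nothing here speaks against carrying the change across. For the compounds shown here, it does not show that the change carries over with the same size, and the one readable step, a 2.0-fold lower number from compound 1 to compound 3 (0.30 log units; within the scatter), is no firm effect even on the first core.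

The compounds shown leave open whether a methoxy group, a nitrile or a trifluoromethyl group in place of the same hydrogen would move the number on either core. Also open, going by these compounds, is whether an exact number for compound 2 would bring the two steps together or set them apart.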